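Moving one methyl group on the piperidine ring

The compounds below may be only part of what the source reports. "The series", "measured", "known", "first", "only" and "open" are said of these compounds alone.

Compound 1 `Cc1ncc([N+](=O)[O-])n1CCSC(=S)N1CCCCC1C` gives 170 ug/mL
Compound 2 `Cc1ncc([N+](=O)[O-])n1CCSC(=S)N1CCC2(CC1)OCCO2` gives > 1000 ug/mL (a limit of the assay, not a number)
Compound 3 `Cc1ncc([N+](=O)[O-])n1CCSC(=S)N1C(C)CCCC1C` gives 130 ug/mL

In an ADME assay on HeLa cells (Homo sapiens) for cytotoxicity (a lower number here means a stronger inhibitor, a higher number a weaker inhibitor), compound 1 gives 170 ug/mL and has one numerical neighbour, compound 3. The result for compound 2 is only a limit. Compound 4 `Cc1ncc([N+](=O)[O-])n1CCSC(=S)N1CCCC(C)C1` is still unmeasured and carries 3-methylpiperidin-1-yl in place of 2-methylpiperidin-1-yl on a thiocarbonyl carbon. Going by the values given here, the one measured step that bears on this puts methyl in place of hydrogen on a saturated ring carbon (a 1.3-fold lower number from compound 1 to compound 3 (0.12 log units; within the scatter)). Moving the methyl is therefore expected to give no step beyond the scatter (a 1.1-fold lower number from compound 1 to compound 4 (0.03 log units; within the scatter)). Compound 4 is expected near 160 ug/mL (estimated range 80 ug/mL to 320 ug/mL).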

Compound 4, half-maximal inhibitory concentration: 170 ug/mL
Compound 4: middle estimate off by 1.1-fold (0.03 log units), on the low side; low and high end bracket the measured number.
By their numbers in this assay, from the lowest: compounds 3, 1 and 4 (each within the scatter of the next). At a limit, above all of these: compound 2.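

In this assay, putting 3-methylpiperidin-1-yl in place of 2-methylpiperidin-1-yl on the thiocarbonyl carbon gives no change at the digits printed from compound 1 to compound 4 (within the scatter). The earlier step added a methyl, whereas this one keeps the same atoms and only moves the methyl, and this move also stays within the scatter. Nothing measured here explains why the number holds.

Still open, on these data alone, is whether 4-methylpiperidin-1-yl would give a similar number. It is also unknown how a piperidine ring carrying an amine or a carboxylic acid would behave.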